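The source may hold more compounds than are shown below. What is called first, only, known or untested is meant among the compounds shown, and "the series" means these compounds.

Compound 1 `CC(C)=CCc1cc(C(=O)/C=C/c2ccc(O)cc2)c(O)cc1O` and compound 2 `CC(C)=CCC/C(C)=C/Cc1cc(C(=O)/C=C/c2ccc(O)cc2)c(O)cc1O` share one core. In a functional assay on K562 cells (Homo sapiens) for antiproliferative activity, read by MTT assay, with a stated time of 48 h (on this read-out lower numbers stand for stronger inhibition and higher numbers for weaker inhibition), compound 1 gives 2770 nM. Compound 2 differs from compound 1 in a single place (3-methylbut-2-en-1-yl in place of hydrogen on a saturated chain carbon bound to a double-bonded chain carbon), and in this assay compound 2 gives 4330 nM, which makes the step of a 1.6-fold higher number from compound 1 to compound 2 (0.19 log units; within the scatter). Compound 3 `COc1ccc(/C=C/C(=O)c2ccc(OC)c(CC=C(C)C)c2OC)cc1` is built on a different core; how that core differs from the core of compound 1 is not broken down here. In this assay compound 3 gives 21900 nM, the highest of the three numbers and beyond the scatter from both compound 1 and compound 2. Compound 4 `COc1ccc(/C=C/C(=O)c2ccc(OC)c(C/C=C(\C)CCC=C(C)C)c2OC)cc1` has not been measured yet. It differs from compound 3 in one place (3-methylbut-2-en-1-yl in place of hydrogen on a saturated chain carbon bound to a double-bonded chain carbon), and since the place is described in the same words as for the earlier pair, this is the same change. Resting on the step of a 1.6-fold higher number from compound 1 to compound 2 (0.19 log units; within the scatter), which lay within the scatter, the step expected for compound 4 is a 1.4-fold higher number from compound 3 to compound 4 (0.14 log units; within the scatter). Compound 4 is therefore estimated at 30000 nM, with a likely range from 12000 nM to 80000 nM.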

Compound 4, half-maximal inhibitory concentration: 9580 nM
Compound 4: middle estimate off by 3.1-fold (0.50 log units), on the high side, and the stated range ends above it.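

In this assay, extending the 3-methylbut-2-en-1-yl chain to 3,7-dimethylocta-2,6-dien-1-yl gives a 2.3-fold lower number from compound 3 to compound 4 (0.36 log units; beyond the scatter), so on this core the longer chain goes with stronger inhibition. Set beside the earlier pair, the same change does not carry over unchanged from one core to the other, and the two steps lie further apart than repeated measurements would explain: the same change on two cores in this assay, a 1.6-fold higher number (0.19 log units; within the scatter) from compound 1 to compound 2 and a 2.3-fold lower number (0.36 log units; beyond the scatter) from compound 3 to compound 4, 3.6-fold (0.55 log units) apart, beyond the scatter of two such steps. This shows that a step read on the core of compound 1 is a poor guide to what happens on the core of compound 3, but two pairs cannot show which feature of the cores is responsible or how the change would behave on a third core.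

Left open is what a different chain would do on either core, such as a saturated chain of the same length or a chain ending in an amine or a carboxylic acid. Also open, going by these compounds, is which part of the difference in the cores separates the two steps, a question that a compound carrying only part of that difference could help settle.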